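The compounds below may be only part of what the source reports. "The series", "measured", "known", "first", "only" and "open" are said of these compounds alone.

Measured compounds:

Compound 1, `CCc1ccc(NC(=O)Nc2cc(C)nc3ccccc23)cc1`, gives 17000 nM in an ADME assay on HepG2 cells (Homo sapiens) for cytotoxicity, with a stated time of 72 h; a higher number here means that more compound is needed for the effect, a lower number that less compound is needed.
Compound 2, `Cc1cc(NC(=O)Nc2ccc(F)cc2)c2ccccc2n1`, reaches only the limit of the assay, > 25000 nM.
Compound 3, `Cc1cc(NC(=O)Nc2ccc(C(N)=O)cc2)c2ccccc2n1`, likewise reaches only the limit of the assay, > 25000 nM.

Compound 3 therefore has no number of its own in this assay, only a limit, and it shares that position with one other compound, as shown by the limit of > 25000 nM in this assay, at which 2 of the 3 values shown sit. Compound 4, `Cc1cc(NC(=O)Nc2ccc(Cl)cc2)c2ccccc2n1`, differs from compound 3 in one place: chloro in place of carbamoyl on an aromatic carbon.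

Among the measured compounds shown here, two measured steps bear on this change, both starting from the single compound with a real number. From compound 1 the step of an at least 1.4-fold higher number from compound 1 to compound 3 (0.16 log units; that floor lies within the scatter) and the step of an at least 1.4-fold higher number from compound 1 to compound 2 (0.16 log units; that floor lies within the scatter) both end at the limit. The direct comparison a step that the two limits leave unreadable from compound 2 to compound 3 cannot be read, since both ends are limits. Nothing here points to a step beyond the scatter in this assay for a change of this kind.

Compound 4 is therefore expected to sit near the limit as well, with an estimate of 22000 nM and a range from 9000 nM to 50000 nM. The expected step is an at least 1.1-fold lower number from compound 3 to compound 4 (0.05 log units; that floor lies within the scatter).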

Compound 4, half-maximal effective concentration: > 25000 nM
Compound 4: a limit, no number (the forecaster's own chance of this, stated with the estimate: 60%); at least 1.1-fold (0.05 log units) between middle value and limit.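

Compound 4 shows that a third group at this place, para to a large group, also ends at the limit in this assay, so chloro joins fluoro and carbamoyl there: the limit of > 25000 nM in this assay, at which 3 of the 4 values shown sit. Putting chloro in place of ethyl gives an at least 1.4-fold higher number from compound 1 to compound 4 (0.16 log units; that floor lies within the scatter), so this change, too, has not been shown to go beyond the scatter. The steps among the three compounds at the limit cannot be read, which means that chloro, fluoro and carbamoyl cannot be put in any order here.

From the compounds shown here alone, it remains open how far past the limit these three compounds lie, and so whether ethyl really differs from them in this assay. A longer chain such as propyl, an amine or a carboxylic acid at this place could show whether a measurable value appears again.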